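The compounds below may be only part of what the source reports. "The series", "measured", "known", "first", "only" and "open" are said of these compounds alone.

Measured so far in a physicochemical assay for lipophilicity, using the shake flask method, measured as octanol-water partition, at pH 7.4; on this read-out lower numbers stand for lower lipophilicity and higher numbers for higher lipophilicity:
compound 1 `CC(=O)N[C@@H]1CCC[C@H](C(=O)Nc2cc(-c3cnn4ccccc34)c(Cl)cn2)C1` — 3.6
compound 2 `CC(=O)N[C@@H]1CCC[C@H](C(=O)Nc2cc(-c3cnc4ccccn34)c(Cl)cn2)C1` — 3
compound 3 `CC(=O)N[C@@H]1CCC[C@H](C(=O)Nc2cc(-c3cnn4c3CCCCC4)c(Cl)cn2)C1` — 3.6

Compound 1 shares the highest reading with compound 3, the two being level at the digits shown; compound 2 is the furthest away, with a number 0.60 log units lower from compound 1 to compound 2 (beyond the scatter).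

The new compound, compound 4 `CC(=O)N[C@@H]1CCC[C@H](C(=O)Nc2cc(-c3cnn4c3CN(C)CC4)c(Cl)cn2)C1`, departs from compound 1 by a group of 10 heavy atoms (7 carbon, 3 nitrogen; one five-membered aromatic ring with 2 hetero atoms, one six-membered non-aromatic ring with 2 hetero atoms) in place of a group of 9 heavy atoms (7 carbon, 2 nitrogen; one five-membered aromatic ring with 2 hetero atoms, one six-membered aromatic ring with 1 hetero atom), on an aromatic carbon.

Going by the values given here, two measured steps bear on this. Exchanging one bicyclic aromatic group for another, step a number 0.60 log units lower from compound 1 to compound 2 (beyond the scatter), was modest but beyond the scatter. Replacing the six-membered aromatic ring by a seven-membered non-aromatic ring with one nitrogen, step no change at the digits printed from compound 1 to compound 3 (within the scatter), left this assay unchanged, so loss of aromaticity on its own did not move the number. Compound 4 goes further: the entering group is non-aromatic and carries three nitrogens and three hydrogen-bond acceptors where the leaving group has two of each. Among the compounds with values here, no measured pair covers the addition of a nitrogen to the saturated ring, so the expectation rests on the counted difference alone and is uncertain. A reduction larger than the step seen for compound 1 to compound 2 is expected, estimated as a number 1.00 log units lower from compound 1 to compound 4 (beyond the scatter).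

Compound 4 is therefore expected to give 2.6, with a range of 1.8 to 3.4.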

Compound 4, distribution coefficient: 2.1
Beside the measured number, compound 4's estimate is 0.50 log units above it, within the range that was stated.
By their numbers in this assay, from the lowest: compound 4; then compound 2; then compounds 1 and 3 (each within the scatter of the next).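

In this assay, a non-aromatic ring at this position no longer gives a number level with compound 1: the step for the six-membered non-aromatic ring with 2 hetero atoms is a number 1.50 log units lower from compound 1 to compound 4 (beyond the scatter), and against the other non-aromatic group it is a number 1.50 log units lower from compound 3 to compound 4 (beyond the scatter), so the read-out here depends on which non-aromatic ring is present and not only on whether the ring is aromatic. The second bicyclic aromatic group does not mark the low end of the range either, since the step to the new group is a number 0.90 log units lower from compound 2 to compound 4 (beyond the scatter), leaving compound 4 with the lowest number of the four. No measurement shown here accounts for the size of these steps.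

Between compound 3 and compound 4, ring size and the hetero atom count change together, so the part played by each cannot be separated. A ring oxygen in place of the methyl-bearing nitrogen, the same nitrogen without its methyl group, or that nitrogen set in the seven-membered ring would each leave open how far the number depends on the methylated amine itself.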